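The compounds below may be only part of what the source reports. "The series", "measured", "known", "first", "only" and "open" are said of these compounds alone.

Compound 1, `CCCn1nc(C(=O)N[C@H]2COc3ccccc3N(C)C2=S)nc1Cc1ccccc1`, was examined in a toxicity assay on HT-29 cells (Homo sapiens) for cytotoxicity; on this read-out higher numbers stand for lower toxicity in this test and lower numbers for higher toxicity in this test. In this assay compound 1 reaches only a limit of the assay, > 100000 nM, and not a number. Two further compounds differ from compound 1 in one place each. Compound 2, `CC(C)Cn1nc(C(=O)N[C@H]2COc3ccccc3N(C)C2=S)nc1Cc1ccccc1`, also gives only a limit in this assay, > 100000 nM. Compound 3, `CN1C(=S)[C@@H](NC(=O)c2nc(Cc3ccccc3)n(CCC(F)(F)F)n2)COc2ccccc21`, likewise stops at a limit in this assay, > 100000 nM. The step from compound 1 to compound 2 is a step that the two limits leave unreadable from compound 1 to compound 2, and the step from compound 1 to compound 3 is a step that the two limits leave unreadable from compound 1 to compound 3; neither size can be read because of the limit of > 100000 nM in this assay, at which 3 of the 3 values shown sit. Compound 4, `CN1C(=S)[C@@H](NC(=O)c2nc(Cc3ccccc3)n(C3CCCC3)n2)COc2ccccc21`, has not yet been measured in this assay. It differs from compound 1 by cyclopentyl in place of propyl on an aromatic nitrogen. Both measured steps from compound 1 alter the same chain on that aromatic nitrogen, and both remain unreadable, so they give no direction and no size for the present change. Going by the values given here, no measured step therefore suggests any movement beyond the scatter. Compound 4 is accordingly expected to sit at about 150000 nM, in a range from 60000 nM to 400000 nM, most probably again as a limit. The step from compound 1 to compound 4 that this estimate means is a step that the limit leaves unreadable from compound 1 to compound 4.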

Compound 4, half-maximal cytotoxic concentration: > 100000 nM
Compound 4: a limit, no number; the forecaster's own chance of this, stated with the estimate: 85%; the middle value is on the limit's open side.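

The steps to compound 4 from compound 1, compound 2 and compound 3 cannot be read in this assay, because all of these results are limits and not numbers: the limit of > 100000 nM in this assay, at which 4 of the 4 values shown sit. The compounds shown leave open whether any of these groups on the aromatic nitrogen changes toxicity in this test at all.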